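This account rests on a few compounds, and the source may have more. Where it says the series, first, only, none or still open, it means among the compounds named here.

Three compounds have numbers in a functional assay on CHO-K1 cells for antagonist activity at transient receptor potential cation channel subfamily V member 1 (Homo sapiens), read by FLIPR; on this read-out higher numbers stand for weaker inhibition and lower numbers for stronger inhibition:

compound 1 `CC(C(=O)NCc1ccc(C(F)(F)F)nc1NC1CCCCC1)c1ccc(NS(C)(=O)=O)c(F)c1` gives 20.4 nM
compound 2 `CCCCN(C)c1nc(C(F)(F)F)ccc1CNC(=O)C(C)c1ccc(NS(C)(=O)=O)c(F)c1` gives 0.8 nM
compound 3 `CC(C(=O)NCc1ccc(C(F)(F)F)nc1N1CCC(C)(C)CC1)c1ccc(NS(C)(=O)=O)c(F)c1` gives 0.3 nM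

Compound 3 stands at the lowest number of the three: its nearest neighbour is compound 2, with a 2.7-fold lower number from compound 2 to compound 3 (0.43 log units; beyond the scatter) separating them, and compound 1 is furthest away, with a 68-fold lower number from compound 1 to compound 3 (1.83 log units; beyond the scatter). Compound 4 `CC(C)OC1CCN(c2nc(C(F)(F)F)ccc2CNC(=O)C(C)c2ccc(NS(C)(=O)=O)c(F)c2)CC1` has not been measured. It differs from compound 3 in one place: 4-isopropoxypiperidin-1-yl in place of 4,4-dimethylpiperidin-1-yl on an aromatic carbon. Among the compounds with values here, none of the measured steps swaps one piperidin-1-yl group for another, so none bears directly on this change. The steps that come closest, a 68-fold lower number from compound 1 to compound 3 (1.83 log units; beyond the scatter) and a 2.7-fold lower number from compound 2 to compound 3 (0.43 log units; beyond the scatter), show that the 4,4-dimethylpiperidin-1-yl group on an aromatic carbon gave the lowest number among the three amines tried, but they say nothing about an isopropoxy group on that ring. Compound 4 keeps the piperidine ring of compound 3, so compound 4 is expected to stay close, with a small rise as the more likely direction, about a 2.0-fold higher number from compound 3 to compound 4 (0.30 log units; within the scatter). Compound 4 is therefore estimated at 0.6 nM, within 0.15 nM to 2.5 nM.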

Compound 4, inhibition constant: 3 nM
Compound 4: middle estimate off by 5.0-fold (0.70 log units), on the low side; the measured number lies above the stated range.
By their numbers in this assay, from the lowest: compound 3; then compound 2; then compound 4; then compound 1.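

At this position, an aromatic carbon next to the ring nitrogen, keeping the piperidine ring does not by itself hold the number: in this assay, moving to the 4-isopropoxypiperidin-1-yl group gives a 10-fold higher number from compound 3 to compound 4 (1.00 log units; beyond the scatter), so the group at the far end of that ring counts. The new group also falls behind the open-chain butyl(methyl)amino group, with a 3.8-fold higher number from compound 2 to compound 4 (0.57 log units; beyond the scatter), which means that among these compounds a piperidine ring does not always rank ahead of that chain. It still improves on the cyclohexylamino group, with a 6.8-fold lower number from compound 1 to compound 4 (0.83 log units; beyond the scatter).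

Whether the oxygen or the isopropyl part accounts for the rise stays open, and a 4-isopropylpiperidin-1-yl or a 4-methoxypiperidin-1-yl group on the same carbon would bear on that. Nothing measured here explains the rise.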